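Cytotoxicity Limits Across Three Anilides and a Fourth

A few compounds are considered here, and "the series" means these few. Any claim that something is new, unique, unknown or untested is made for them only; others in the source may bear on it.

Compound 1 `COc1cc(NC(=O)c2ccc(C#N)cc2)ccc1NS(C)(=O)=O` and compound 2 `COc1cc(NC(=O)c2cccc(C(F)(F)F)c2)ccc1NS(C)(=O)=O` share a core whose difference between them is not broken down here. In an ADME assay on HEK293 cells (Homo sapiens) for cytotoxicity, read by MTT assay, with a stated time of 48 h (on this read-out lower numbers stand for stronger inhibition and higher numbers for weaker inhibition), compound 1 gives > 250000 nM, which is a limit of the assay rather than a number. Compound 2 gives > 250000 nM, also a limit. Compound 3 `CS(=O)(=O)Nc1ccc(NC(=O)c2ccc(C#N)cc2)cc1Cl` arises from compound 1 by chloro in place of methoxy on an aromatic carbon, and in this assay compound 3 gives > 250000 nM, again a limit. The step that the two limits leave unreadable from compound 1 to compound 3 cannot be read because of the limit of > 250000 nM in this assay, at which 3 of the 3 values shown sit. Compound 4 `CS(=O)(=O)Nc1ccc(NC(=O)c2cccc(C(F)(F)F)c2)cc1Cl` arises from compound 2 by the same change, (chloro in place of methoxy on an aromatic carbon). The step that the limit leaves unreadable from compound 2 to compound 4 is expected to be small, resting on the three limits described. Compound 4 is therefore estimated at 300000 nM, most likely reported only as a limit.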

Compound 4, half-maximal inhibitory concentration: > 250000 nM
Compound 4: no number, only a limit; the forecaster's own chance of this, stated with the estimate: 90%; the middle value does not contradict the limit.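

For the compounds shown here, compound 2 and compound 4 both give only a limit, so no step between them can be read: the limit of > 250000 nM in this assay, at which 4 of the 4 values shown sit. In this assay the compounds shown leave open how far chloro in place of methoxy changes cytotoxicity.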